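This account rests on a few compounds, and the source may have more. Where it says the series, first, only, none or still open, it means among the compounds named here.

Measured compounds:
- compound 1 `CC(=O)OC[C@H]1O[C@@H](n2cc(-c3cn(Cc4ccc(C(C)(C)C)cc4)nn3)c(=O)[nH]c2=O)C[C@@H]1OC(C)=O` — 94.2%
- compound 2 `CC(=O)OC[C@H]1O[C@@H](n2cc(-c3cc(C)no3)c(=O)[nH]c2=O)C[C@@H]1OC(C)=O` — 102%

Both measured compounds have been tested in a functional assay on HCT-15 cells (Homo sapiens) for cytotoxicity, read by sulforhodamine B assay, tested at 10 uM; a lower number here means less inhibition, a higher number more inhibition at the concentration tested (going by the name of the read-out). Compound 2 gives 102% in this assay, and compound 1 gives 94.2%; the gap between the two falls within the scatter, so neither can be placed ahead of the other, and the two numbers read as level.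

Compound 3 `CCc1ccc(-c2cc(-c3cn([C@H]4C[C@H](OC(C)=O)[C@@H](COC(C)=O)O4)c(=O)[nH]c3=O)on2)cc1` is the next member. It differs from compound 2 in one place: 4-ethylphenyl in place of methyl on an aromatic carbon. Among the measured compounds shown here, no step between measured compounds exists to anchor the size of this change, and with both measured numbers already high in this assay there is little room to move upward.

The step from compound 2 to compound 3 is expected to be a number 7 percentage points lower from compound 2 to compound 3 (within the scatter), none beyond the scatter. Compound 3 is therefore estimated at 95% in this assay, with a range from 78% to 106%.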

Compound 3, a percentage reported as inhibition, at one concentration (the size of the read-out at that concentration, not a potency): 92.2%
Beside the measured number, compound 3's estimate is 2.8 percentage points above it, and the stated range covers the measured number.
By their numbers in this assay, from the lowest: compounds 3, 1 and 2 (each within the scatter of the next).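

In this assay, among the compounds shown here, the first step at this position is a number 9.8 percentage points lower from compound 2 to compound 3 (within the scatter), with 4-ethylphenyl in place of methyl on an aromatic carbon of the five-membered aromatic ring with 1 nitrogen and 1 oxygen. The position therefore takes a group of 8 heavy atoms carrying a six-membered aromatic ring in place of a single carbon while the reading stays level, and a large aryl group here leaves the high inhibition intact at the concentration tested. Nothing measured explains why the reading holds across this change.

Going by these compounds, what an amine or a carboxylic acid at this ring carbon would give remains open. On these data alone, with all readings so high at a single concentration, it is also open whether compound 2 and compound 3 would separate in a potency measurement.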